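A Single Ring Stereocentre Inverted Among Long-Lived Compounds

A few compounds are considered here, and "the series" means these few. Any claim that something is new, unique, unknown or untested is made for them only; others in the source may bear on it.

In an ADME assay on Jejunum (Mus musculus, strain C57BL/6) for metabolic stability, read by HPLC, with a stated time of 12 h (on this read-out lower numbers stand for a shorter-lived compound and higher numbers for a longer-lived compound), compound 1 (`O=C(O)[C@H](CO)NC(=O)[C@H]1C[C@H](O)CN1`) gives > 12 h as a limit and not a number. Compound 2 (`O=C(O)[C@@H](CO)NC(=O)[C@H]1C[C@@H](O)CN1`) gives > 12 h as a limit too. Against compound 2, compound 3 (`O=C(O)[C@@H](CO)NC(=O)[C@H]1C[C@H](O)CN1`) shows this change: the two compounds have the same atoms and bonds and differ only in configuration as drawn: 1 of 3 stereo elements differ; a stereocentre at a saturated ring carbon is drawn R in compound 2 and S in compound 3 and nothing else. Within the data shown here, the one measured step bearing on it is a step that the two limits leave unreadable from compound 1 to compound 2 and it offers no size to carry forward, so no change beyond the scatter is expected in this assay here. The expected step is a step that the limit leaves unreadable from compound 2 to compound 3 in this estimate. Compound 3 is estimated at 14 h with a range from 8 h to 28 h. Compound 3 is expected to give only a limit as well.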

Compound 3, half-life: > 12 h
Compound 3: a limit, no number (the forecaster's own chance of this, stated with the estimate: 85%); the middle value is on the limit's open side.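

Among these compounds, compound 1, compound 2 and compound 3 each give only a limit in this assay, so no step between them can be read. From the compounds shown here alone, their actual half-lives, and whether configuration changes them at all, remain open.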